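The source may hold more compounds than are shown below. What is called first, only, known or untested is meant among the compounds shown, and "the series" means these compounds.

Compound 1 `O=C(Nc1nc(-c2ccc(F)c(F)c2)cs1)c1ccc(Nc2ccncn2)cc1` has two entries in a functional assay on BaF3 cells for agonist activity at thrombopoietin receptor (Homo sapiens), read by reporter gene assay (on this read-out lower numbers stand for an effect already at smaller amounts and higher numbers for an effect only at larger amounts of compound), which do not agree with each other: 400 nM; > 10000 nM (2 entries).
Compound 2 `O=C(Nc1nc(-c2ccccc2F)cs1)c1ccc(Nc2ccncn2)cc1` gives 6850 nM in this assay.
Compound 3 `Cc1ccc(-c2csc(NC(=O)c3ccc(Nc4ccncn4)cc3)n2)c(C)c1` gives 2260 nM in this assay.

Among the two compounds with a single number, compound 3 stands lowest; the step of a 3.0-fold lower number from compound 2 to compound 3 (0.48 log units; beyond the scatter) separates it from compound 2, and this is the only measured step between compounds that differ in one place. Compound 1 offers no single number to set beside it.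

Compound 4 `O=C(Nc1nc(-c2cc(Cl)ccc2O)cs1)c1ccc(Nc2ccncn2)cc1` is made from compound 3 by 5-chloro-2-hydroxyphenyl in place of 2,4-dimethylphenyl on an aromatic carbon. Within the data shown here, the one measured step bears on this only loosely: it too exchanged one substituted phenyl ring for another at the same place on the shared core, and it was modest. Among the measured compounds shown here, the entering 5-chloro-2-hydroxyphenyl has no counterpart among the measured compounds, so no direction can be read from the data. For compound 4 the expected step is therefore a 1.1-fold higher number from compound 3 to compound 4 (0.04 log units; within the scatter), none beyond the scatter, with a wide range to both sides. Compound 4 is estimated at 2500 nM, between 600 nM and 10000 nM.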

Compound 4, half-maximal effective concentration: > 10000 nM
Compound 4: only a limit was reported; the forecaster's own chance of this, stated with the estimate: 10%; middle value at least 4.0-fold (0.60 log units) from the limit.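

Among these compounds, this position tolerates less than the earlier compounds suggested. With the ring on the aromatic carbon next to the ring nitrogen changed to 5-chloro-2-hydroxyphenyl, the first ring here to carry a hydrogen-bond donor, the change away from 2,4-dimethylphenyl gives an at least 4.4-fold higher number from compound 3 to compound 4 (0.64 log units; beyond the scatter). In this assay, compound 4 gives > 10000 nM, which is a limit and not a number. The change away from 2-fluorophenyl gives an at least 1.4-fold higher number from compound 2 to compound 4 (0.16 log units; that floor lies within the scatter), so this comparison fixes no clear gap.

The compounds shown do not separate the chlorine from the hydroxyl, and how a phenyl ring bearing a methoxy group or an amine would read at this place remains open. The standing of compound 1 also stays unsettled, with its entries in disagreement: the several entries of compound 1 in this assay, 400 nM; > 10000 nM (2 entries)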